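The compounds below may be only part of what the source reports. "The series", "measured", "known", "first", "only" and "open" are said of these compounds alone.

Compound 1 `CCn1c(C(=O)NCCN(C)C)ccc1C(CC)(CC)c1ccc(OCCC(O)(CC)CC)c(C)c1` is the reference point. In a functional assay on Caco-2 cells (Homo sapiens) for antiproliferative activity, read by MTT assay, with a stated time of 48 h (on this read-out lower numbers stand for stronger inhibition and higher numbers for weaker inhibition), compound 1 gives 1140 nM. Compound 2 `CCN(CC)CCNC(=O)c1ccc(C(CC)(CC)c2ccc(OCCC(O)(CC)CC)c(C)c2)n1CC` differs only at the end of the amide side chain, and in this assay compound 2 gives 1630 nM; the step of a 1.4-fold higher number from compound 1 to compound 2 (0.16 log units; within the scatter) is too small to count as a real change. Compound 3 `CCn1c(C(=O)NCC#N)ccc1C(CC)(CC)c1ccc(OCCC(O)(CC)CC)c(C)c1` carries a nitrile where the two earlier compounds carry an amine. For compound 3 this assay reports only the limit > 50000 nM, which is not a number but the edge of what the assay measures; this is the limit of > 50000 nM in this assay, at which 1 of the 3 values shown sits. The steps of an at least 43-fold higher number from compound 1 to compound 3 (1.64 log units; beyond the scatter) and an at least 30-fold higher number from compound 2 to compound 3 (1.48 log units; beyond the scatter) are both large losses of activity.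

Compound 4 `CCn1c(C(=O)N(CCC#N)CCC#N)ccc1C(CC)(CC)c1ccc(OCCC(O)(CC)CC)c(C)c1` moves on from compound 3 with a group of 9 heavy atoms (6 carbon, 3 nitrogen; no ring) in place of a group of 4 heavy atoms (2 carbon, 2 nitrogen; no ring), on a carbonyl carbon. Among the measured compounds shown here, compound 4 again has no amine and keeps nitrile groups, now two of them, so the two large losses seen on reaching compound 3 are the only steps that bear on it, and no recovery is expected. The expected step that the limit leaves unreadable from compound 3 to compound 4 is therefore essentially none, and compound 4 is estimated at 70000 nM, with a range of 20000 nM to 250000 nM, most likely again reported only as a limit.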

Compound 4, half-maximal inhibitory concentration: > 50000 nM
Compound 4 gave a limit, no number; the forecaster's own chance of this, stated with the estimate: 80%; the middle value is on the limit's open side.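

Compound 4 also ends at a limit in this assay, not at a number: the limit of > 50000 nM in this assay, at which 2 of the 4 values shown sit.

Among the compounds shown here, the large loss is therefore not tied to the single small nitrile group of compound 3: a larger group on the carbonyl carbon, with two nitriles and no hydrogen-bond donor, shows it too, with an at least 43-fold higher number from compound 1 to compound 4 (1.64 log units; beyond the scatter) and an at least 30-fold higher number from compound 2 to compound 4 (1.48 log units; beyond the scatter). Compound 3 and compound 4 both stand at limits, and the step between them cannot be read.

As far as these compounds go, only compound 1 and compound 2 carry an amine, and both keep the amide hydrogen, so it stays open whether an amine chain would hold its activity with that hydrogen replaced. Also open, from the compounds shown here alone, is how a carboxylic acid or a longer amine chain would read in this place.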